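Swapping dimethylpiperidine for methylpiperazine on a shared core

The source may report more compounds than this note shows. Statements on the series, on what has been measured and on what is new or still open speak of the compounds shown alone.

Compound 3 `CC1CC(C)CN(CC(=O)N2N=C(c3cc4ccccc4oc3=O)CC2c2ccccc2)C1` stands apart from its measured relatives: in a functional assay on PC-3 cells (Homo sapiens) for cytotoxicity, read by MTT assay, with a stated time of 48 h (a higher number here means a weaker inhibitor, a lower number a stronger inhibitor), compound 3 is reported as "not active" (no number reported), with no number given. The relatives do give numbers: in this assay compound 1 `CC(C)(C)NCC(=O)N1N=C(c2cc3ccccc3oc2=O)CC1c1ccccc1` gives 16400 nM, and compound 2 `CC1CCCN(CC(=O)N2N=C(c3cc4ccccc4oc3=O)CC2c2ccccc2)C1` gives 28300 nM. Within the data shown here, the step of a 1.7-fold higher number from compound 1 to compound 2 (0.24 log units; within the scatter) is the only measured exchange of one amine for another at this position and bears most closely on the question here. Compound 4 `CN1CCN(CC(=O)N2N=C(c3cc4ccccc4oc3=O)CC2c2ccccc2)CC1` is made from compound 3 by the change (4-methylpiperazin-1-yl in place of 3,5-dimethylpiperidin-1-yl on a saturated chain carbon bound to a carbonyl carbon). Among the measured compounds shown here, no measured step mirrors this exact exchange, so the expectation rests on every amine seen so far giving a weak number. Compound 4 is therefore expected to stay weak in this assay, with an estimated 35000 nM and a range from 12000 nM to 100000 nM.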

Compound 4, half-maximal inhibitory concentration: 25800 nM
Compound 4: the middle estimate sits 1.4-fold (0.13 log units) above what was measured; the range from low to high includes it.
By their numbers in this assay, from the lowest: compounds 1, 4 and 2 (each within the scatter of the next).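

In this assay, compound 4 with 4-methylpiperazin-1-yl gives a number, whereas compound 3 with 3,5-dimethylpiperidin-1-yl is reported without one, so this change cannot be read as a step. Compared with the other amines, the ring with 2 hetero atoms stays within the scatter, with a 1.1-fold lower number from compound 2 to compound 4 (0.04 log units; within the scatter) and a 1.6-fold higher number from compound 1 to compound 4 (0.20 log units; within the scatter). Nothing measured here explains these results. Still open, on these data alone, is whether any group on this saturated chain carbon gives a much lower number. A morpholin-4-yl ring or a longer chain carrying the amine would test this.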